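Metabolic Stability Across Amide Changes on a Shared Core

The source may report more compounds than this note shows. Statements on the series, on what has been measured and on what is new or still open speak of the compounds shown alone.

Compound 1 `O=C(CCc1ccccc1)NCc1ccc2[nH]c(=O)c(-c3nccs3)c(CCc3ccccc3)c2c1`: 3%
Compound 2 `CS(=O)(=O)c1c(CCc2ccccc2)c2cc(OCC(=O)Nc3ccccc3)ccc2[nH]c1=O`: 67%
Compound 3 `O=C(COc1ccc2[nH]c(=O)c(-c3nccs3)c(CCc3ccccc3)c2c1)NC1(c2ccccc2)CC1`: 46%

Of the compounds shown here, three built on a shared core have been measured in an ADME assay on microsomes from liver (Homo sapiens) for metabolic stability, with a stated time of 0.5 h; on this read-out higher numbers stand for a more stable compound and lower numbers for a less stable compound. Compound 2 gives the highest of the three numbers, 67%; compound 3 lies nearest to it, lower by a gap beyond the scatter, and compound 1 lies furthest, also beyond the scatter. Compound 4 `CN(Cc1ccc(Cl)c(Cl)c1)C(=O)COc1ccc2[nH]c(=O)c(S(C)(=O)=O)c(CCc3ccccc3)c2c1` has not yet been measured in this assay. It differs from compound 2 in one place: (3,4-dichlorobenzyl)(methyl)amino in place of anilino on a carbonyl carbon. For the measured compounds named here, no step between two measured compounds carries this change, so the expectation rests on compound 2 alone. The step of a number 22 percentage points lower from compound 2 to compound 4 (beyond the scatter) is expected to be a moderate decrease in this assay, rather than no change. Compound 4 is estimated at 45%, with a range from 20% to 70%.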

Compound 4, percent of the compound remaining: 0%
For compound 4 the middle estimate is 45 percentage points above the measured one; measured number outside the range, below it.
By their numbers in this assay, from the lowest: compounds 4 and 1 (each within the scatter of the next); then compound 3; then compound 2.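

Within this assay, placing (3,4-dichlorobenzyl)(methyl)amino in place of anilino on a carbonyl carbon gives a number 67 percentage points lower from compound 2 to compound 4 (beyond the scatter) and shows that this one place on the shared core can carry the number across nearly the whole range seen so far. A change here alone is enough to separate a well-retained compound from one with nothing left. Nothing available explains the step. The change also swaps several features at once, including the amide hydrogen, the chlorine atoms and the added methyl. As far as these compounds go, how a plain benzylamino group would behave here remains open.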